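This account rests on a few compounds, and the source may have more. Where it says the series, first, only, none or still open, it means among the compounds named here.

Among the measured compounds shown here, in a physicochemical assay for solubility, read by HPLC, with a stated time of 24 h (on this read-out higher numbers stand for higher solubility and lower numbers for lower solubility), compound 2 `O=C1CSC(=O)N1C[C@H]1CN(c2ccc(-n3cc(-c4ccccn4)cn3)c(F)c2)C(=O)O1` gives 26900 nM, the only plain number among the three measured compounds. Compound 1 `O=C1O[C@@H](CN2CCC(c3ccc(F)cc3)CC2)CN1c1ccc(-n2cc(-c3ccccn3)cn2)c(F)c1` gives <= 19400 nM, which is a limit of the assay rather than a number, namely (the limit of <= 19400 nM in this assay, at which 1 of the 3 values shown sits). Compound 3 `O=C(OC[C@H]1CN(c2ccc(-n3cc(-c4ccccn4)cn3)c(F)c2)C(=O)O1)c1ccccc1` likewise gives <= 65400 nM, again a limit, namely (the limit of <= 65400 nM in this assay, at which 1 of the 3 values shown sits). For the measured compounds named here, the single one-place step, a step that the limit leaves unreadable from compound 2 to compound 3, therefore cannot be sized. Compound 4 `O=CNC[C@H]1CN(c2ccc(-n3cc(-c4ccccn4)cn3)c(F)c2)C(=O)O1` differs from compound 2 by formylamino in place of 2,4-dioxo-1,3-thiazolidin-3-yl on a saturated chain carbon bound to a saturated ring carbon. Going by the values given here, no measured step covers this change, so the expectation rests on compound 2 alone. The step of a 1.7-fold higher number from compound 2 to compound 4 (0.22 log units; within the scatter) is estimated to be modest, toward higher solubility, and may not exceed the scatter. Compound 4 is thus expected to show about 45000 nM in this assay, within a range from 15000 nM to 130000 nM.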

Compound 4, solubility: 217000 nM
Compound 4: the middle estimate sits 4.8-fold (0.68 log units) below what was measured; the measured number lies above the stated range.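

In this assay, formylamino in place of 2,4-dioxo-1,3-thiazolidin-3-yl on a saturated chain carbon bound to a saturated ring carbon gives an 8.1-fold higher number from compound 2 to compound 4 (0.91 log units; beyond the scatter), so the number at this position clearly depends on the group it carries. Formylamino in place of benzoyloxy gives an at least 3.3-fold higher number from compound 3 to compound 4 (0.52 log units; beyond the scatter), so formylamino also reads higher than a second group here. That second step rests on a limit for compound 3, not a number: the limit of <= 65400 nM in this assay, at which 1 of the 4 values shown sits.

Which part of the change carries the rise, the lost ring or the added hydrogen-bond donor, stays open. Also open, going by these compounds, is whether a plain amine or an acetylamino group at this place would read as high.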